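Ring group exchange from compound 2 to compound 3

This account rests on a few compounds, and the source may have more. Where it says the series, first, only, none or still open, it means among the compounds named here.

In an ADME assay on BSC cells (Rattus norvegicus) for cytotoxicity (on this read-out lower numbers stand for narrower zones and higher numbers for wider zones without growth), compound 1 `COC1=C(C)C(=O)O/C1=C\C(C)CCC/C(C)=C/CC/C(C)=C/CCC1=CC(O)OC1=O` gives 4 mm and compound 2 `COC1=C(C)C(=O)O/C1=C\C(C)CCC/C(C)=C/CC/C(C)=C/CCC1=CC(=O)OC1O` gives 2 mm on the same read-out. Among the measured compounds shown here, these are the only two numbers so far, and compound 2 stands within the scatter of compound 1.

Compound 3 `COC1=C(C)C(=O)O/C1=C\C(C)CCC/C(C)=C/CC/C(C)=C/CCC1(O)C(OC)OC(OC)C1O` has not yet been measured. Its difference from compound 2 is a group of 11 heavy atoms (6 carbon, 5 oxygen; one five-membered non-aromatic ring with 1 hetero atom) in place of a group of 7 heavy atoms (4 carbon, 3 oxygen; one five-membered non-aromatic ring with 1 hetero atom), on a saturated chain carbon, two bonds along the chain from a double-bonded chain carbon and the entering group is 3,4-dihydroxy-2,5-dimethoxyoxolan-3-yl.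

For the measured compounds named here, one measured step bears on this change, since it also exchanges one ring group for another at the same place on the chain. Going by the values given here, that step is a number 2.0 mm lower from compound 1 to compound 2 (within the scatter) and it is the only guide available. Among the compounds with values here, no measured compound carries the entering group, so the guide is thin. On the basis of a number 2.0 mm lower from compound 1 to compound 2 (within the scatter) no step beyond the scatter is expected in this assay and the estimated step is no change at the digits printed from compound 2 to compound 3 (within the scatter) on that reading. For compound 3 the estimate is 2 mm with an expected range from 0 mm to 5 mm in this measurement.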

Compound 3, diameter of the zone without growth: 1 mm
Compound 3: middle estimate off by 1.0 mm, on the high side, and the stated range covers the measured number.
By their numbers in this assay, from the lowest: compounds 3, 2 and 1 (each within the scatter of the next, the first and the last beyond it).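

In this assay the position takes the 3,4-dihydroxy-2,5-dimethoxyoxolan-3-yl group, with more heavy atoms than the ring group of compound 2, without a step that can be read as a change (a number 1.0 mm lower from compound 2 to compound 3 (within the scatter)), so compound 2 and compound 3 are not separated on this read-out. Among the compounds shown here, the same exchange at this saturated chain carbon now gives the first pair that stands apart, a modest step (a number 3.0 mm lower from compound 1 to compound 3 (beyond the scatter)), whereas compound 2 remains within the scatter of both compound 1 and compound 3, so the three ring groups do not fall into clearly separate levels. No measurement on hand accounts for either step.

Open, as far as these compounds go, is whether any ring group is needed at this place, since all three compounds carry a five-membered non-aromatic ring with 1 hetero atom there, and a carboxylic acid or an amine on the same chain carbon would test that. Also open, from the compounds shown here alone, is which part of the entering group goes with the step from compound 1, the hydroxy groups or the methoxy groups, as the two always enter together here.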